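Solubility notes: pyrimidinyl replacing aminophenyl on the shared core

The compounds below may be only part of what the source reports. "The series", "measured", "known", "first", "only" and "open" are said of these compounds alone.

For the measured compounds named here, compound 3 `Cc1cc(NCc2ccccn2)n2ncc(-c3cccc(N)c3)c2n1` gives 160000 nM in a physicochemical assay for solubility, read by HPLC, using the shake flask method, measured as kinetic solubility, with a stated time of 2 h, at pH 7.4 (a higher number here means a more soluble compound, a lower number a less soluble compound), the only full number in the set. Compound 1 `Cc1cc(NCc2ccccn2)n2ncc(-c3ccc(F)cc3)c2n1` gives < 5000 nM in this assay, a limit of the assay. Compound 2 `Cc1cc(NCc2ccccn2)n2ncc(-c3ccc(F)c(Cl)c3)c2n1` gives < 5000 nM in this assay, again a limit. Going by the values given here, compound 3 therefore stands as the one compound with a readable value; two values sit at the limit of < 5000 nM in this assay, at which 2 of the 3 values shown sit.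

Compound 4 `Cc1cc(NCc2ccccn2)n2ncc(-c3cncnc3)c2n1` is not yet measured. Its change from compound 3 is pyrimidin-5-yl in place of 3-aminophenyl on an aromatic carbon. Among the compounds with values here, no measured step exchanges one aromatic ring for another heteroaromatic ring of this kind. Within the data shown here, the steps that bear on the place are an at least 32-fold higher number from compound 1 to compound 3 (1.50 log units; beyond the scatter) and an at least 32-fold higher number from compound 2 to compound 3 (1.50 log units; beyond the scatter), both large, and a step that the two limits leave unreadable from compound 1 to compound 2. Of these, both readable steps run toward compound 3, so the group at this position moves the number strongly.

For compound 4 a step of a 5.3-fold lower number from compound 3 to compound 4 (0.73 log units; beyond the scatter) in this assay is expected, downward from compound 3, because the readable steps of an at least 32-fold higher number from compound 1 to compound 3 (1.50 log units; beyond the scatter) and an at least 32-fold higher number from compound 2 to compound 3 (1.50 log units; beyond the scatter) all lead away from the groups without the 3-aminophenyl. Compound 4 is estimated at 30000 nM, with a range from 5000 nM to 150000 nM.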

Compound 4, solubility: 111000 nM
Beside the measured number, compound 4's estimate is 3.7-fold (0.57 log units) below it; the range from low to high includes it.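

At this place on the five-membered aromatic ring, this assay gives a 1.4-fold lower number from compound 3 to compound 4 (0.16 log units; within the scatter), so pyrimidin-5-yl and 3-aminophenyl cannot be told apart, and a readable value in this set no longer rests on 3-aminophenyl or its hydrogen-bond donor alone. A second, quite different ring now stands clear of both halogen-bearing phenyl groups, with an at least 22-fold higher number from compound 1 to compound 4 (1.34 log units; beyond the scatter) and an at least 22-fold higher number from compound 2 to compound 4 (1.34 log units; beyond the scatter). Both of these steps start from a limit of the assay, so their full size stays unread: the limit of < 5000 nM in this assay, at which 2 of the 4 values shown sit.

Open, as far as these compounds go, is whether plain phenyl, carrying neither fluoro nor chloro, would sit with compound 1 and compound 2 or with compound 3 and compound 4. Also open, from the compounds shown here alone, is whether pyridin-3-yl, with a single ring nitrogen, would match pyrimidin-5-yl at this place.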